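This account rests on a few compounds, and the source may have more. Where it says the series, first, only, none or still open, it means among the compounds named here.

Measured compounds:
compound 1, `Cc1ccc(Nc2ncc(C(=O)Nc3cc(NC(=O)c4cccc(C(F)(F)F)c4)ccc3C)cn2)cc1N`: 330 nM
compound 2, `CNc1nc(Nc2ccc(C)c([N+](=O)[O-])c2)ncc1C(=O)Nc1cc(NC(=O)c2ccc(OC)cc2)ccc1C`: 1530 nM

Both numbers come from a functional assay on K562 cells (Homo sapiens) for antiproliferative activity, read by CellTiter-Glo and CCK-8 assay, with a stated time of 72 h; a higher number here means a weaker inhibitor of growth, a lower number a stronger inhibitor of growth. Among the two measured compounds, compound 2 holds the highest number; its nearest neighbour, compound 1, sits at a lower number, and the gap between them lies beyond the usual scatter of repeated measurements. Compound 3, `CNc1nc(Nc2ccc(C)c([N+](=O)[O-])c2)ncc1C(=O)Nc1cc(NC(=O)c2ccc3c(c2)OCCO3)ccc1C`, has not yet been measured. It differs from compound 2 in one place: 2,3-dihydro-1,4-benzodioxin-6-yl in place of 4-methoxyphenyl on a carbonyl carbon. Everything else in the molecule is kept as in compound 2. Within the data shown here, no measured pair shows what this particular exchange does, so the expectation for compound 3 rests on the structural change alone, which keeps one aromatic ring at the same carbonyl carbon and adds a second ring that brings one more hydrogen-bond acceptor. Such a change is expected to move the number in this assay only a little, with no step beyond the scatter in either direction, so the expected step is a 1.2-fold lower number from compound 2 to compound 3 (0.07 log units; within the scatter). Compound 3 is accordingly estimated at 1300 nM, within a range from 500 nM to 3500 nM.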

Compound 3, concentration for 50% growth inhibition: 320 nM
The estimate for compound 3 lay 4.1-fold (0.61 log units) above the measured number; the whole stated range lies above it.
By their numbers in this assay, from the lowest: compounds 3 and 1 (each within the scatter of the next); then compound 2.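

In this assay, among these compounds, placing 2,3-dihydro-1,4-benzodioxin-6-yl in place of 4-methoxyphenyl on a carbonyl carbon gives a 4.8-fold lower number from compound 2 to compound 3 (0.68 log units; beyond the scatter) and so shows that this position responds to the exchange, which no earlier pair could show. Both groups keep a six-membered aromatic ring of carbon only at the same carbonyl carbon, and the entering group adds a six-membered non-aromatic ring with 2 hetero atoms, so the step is tied to that one structural difference and not to any other part of the molecule. No measurement here accounts for the size of the step or gives a reason for it.

The compounds shown leave open whether the closed ring or simply the added oxygen carries the step: 3,4-dimethoxyphenyl, with both oxygens in open methoxy groups, or 1,3-benzodioxol-5-yl, with a smaller closed ring, would separate the two. As far as these compounds go, it also remains open whether the same exchange gives a similar step on the core of compound 1, which has a primary amine in place of the nitro group and lacks the methylamino group.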